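A few compounds are considered here, and "the series" means these few. Any claim that something is new, unique, unknown or untested is made for them only; others in the source may bear on it.

In a functional assay on HCT-116 cells (Homo sapiens) for cytotoxicity, read by MTT assay, with a stated time of 48 h (a higher number here means a weaker inhibitor, a lower number a stronger inhibitor), compound 1 (`O=C(CSCc1nc2cc([N+](=O)[O-])ccc2[nH]1)c1ccccc1`) gives 12400 nM. Compound 2 (`CCOC(=O)c1c(NC(=O)CSCc2nc3cc([N+](=O)[O-])ccc3[nH]2)sc2c1CCCCC2`) gives 7510 nM, and these two values lie within the usual scatter of each other. For the measured compounds named here, compound 1 therefore stands level with the only other measured compound, and neither can be called the better inhibitor.

Compound 3 (`NC(=O)CSCc1nc2cc([N+](=O)[O-])ccc2[nH]1`) keeps the core of compound 1 but carries amino in place of phenyl on a carbonyl carbon. This swaps a ring for a single nitrogen, and neither measured compound shows what so small a group does in this assay. Any forecast must therefore stay loose. A moderate move toward a higher number, meaning a weaker inhibitor, is expected, and the estimated step is a 2.0-fold higher number from compound 1 to compound 3 (0.30 log units; within the scatter). For compound 3 the estimated value is 25000 nM, with an expected range from 9000 nM to 70000 nM.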

Compound 3, half-maximal inhibitory concentration: 17200 nM
Compound 3: the middle estimate sits 1.5-fold (0.16 log units) above what was measured; the measured number falls inside the stated range.
By their numbers in this assay, from the lowest: compounds 2, 1 and 3 (each within the scatter of the next, the first and the last beyond it).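

In this assay, amino in place of phenyl on a carbonyl carbon gives a 1.4-fold higher number from compound 1 to compound 3 (0.14 log units; within the scatter) and so leaves the two compounds level. For the compounds shown here, this is the first direct comparison at this place, and it shows that, for this pair, a single nitrogen can stand where a six-membered aromatic ring of six carbons stood without the number moving beyond the usual scatter. The data offer no measured explanation for this result.

The compounds shown do not reveal whether any group on this carbonyl carbon can move the number beyond the scatter in either direction. On these data alone, a methylamino group, a cyclohexyl ring or a phenyl ring carrying a chlorine atom might separate the effect of ring size from that of the amide hydrogen, but their effects remain open.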